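Aryl ether variation and passive permeability in the series

This account rests on a few compounds, and the source may have more. Where it says the series, first, only, none or still open, it means among the compounds named here.

Two members of the series have been run in an ADME assay for permeability, using PAMPA, with a stated time of 4 h; a lower number here means that the compound crosses the layer more slowly, a higher number that the compound crosses the layer faster. Compound 1 `Cn1c(COc2cccc(C(=O)O)c2)nc2cnc(Oc3ccc(Cl)c(F)c3)cc21` gives 11.2 10^-6 cm/s. Compound 2 `Cn1c(COc2cccc(C(=O)O)c2)nc2ccc(Oc3ccccn3)cc21` gives 2.2 10^-6 cm/s, the lowest of the two numbers; its gap to compound 1 lies beyond the scatter. For the measured compounds named here, no pair among the measured compounds differs in a single place, so no single step has been isolated.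

Compound 3 `Cn1c(COc2cccc(C(=O)O)c2)nc2ccc(Oc3ncc(Cl)cc3Cl)cc21` takes the next step from compound 2: 3,5-dichloropyridin-2-yl in place of pyridin-2-yl on an oxygen on an aromatic ring. The exchange keeps the (pyridin-2-yl)oxy link on the aromatic carbon and adds the two chlorines within that ring.

Compound 3 is expected to move upward in this assay, by about a 2.7-fold higher number from compound 2 to compound 3 (0.44 log units; beyond the scatter), an expectation resting on compound 2 being the lowest number seen and on compound 1 giving 11.2 10^-6 cm/s with its own substituted aryl ether. For compound 3 the estimate is 6 10^-6 cm/s, with a range from 2.5 10^-6 cm/s to 14 10^-6 cm/s.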

Compound 3, apparent permeability: 16.1 10^-6 cm/s
For compound 3 the middle estimate is 2.7-fold (0.43 log units) below the measured one; measured number above the stated range.
By their numbers in this assay, from the lowest: compound 2; then compounds 1 and 3 (each within the scatter of the next).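

For the compounds shown here, compound 2 and compound 3 are the first pair that differ in one place, so the exchange of (pyridin-2-yl)oxy for (3,5-dichloropyridin-2-yl)oxy can now be read on its own in this assay: the step is a 7.3-fold higher number from compound 2 to compound 3 (0.86 log units; beyond the scatter) and lies beyond the scatter. With the rest of the structure unchanged, the two chlorines on this ring go with a higher number, not a lower one. No measurement available here bears on what lies behind the step.

As far as these compounds go, whether a single chlorine on the pyridine ring gives part or all of this step remains open, as does the outcome with a methyl group, a fluorine or a nitrile there instead. Also open, from the compounds shown here alone, is whether the step would hold if the carboxylic acid were replaced by an amide.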